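Swapping the indole of compound 1 for a fused bicyclic heteroaryl

The source may report more compounds than this note shows. Statements on the series, on what has been measured and on what is new or still open speak of the compounds shown alone.

Of the compounds shown here, two have been tested in a functional assay on A549 cells (Homo sapiens) for inhibition, read by MTT assay, with a stated time of 72 h; on this read-out lower numbers stand for stronger inhibition and higher numbers for weaker inhibition. Compound 1, with the structure `Nc1ccccc1NC(=O)c1ccc(CNC(=O)/C=C/c2c[nH]c3ccccc23)cc1`, gives 649 nM in this assay. Compound 2, with the structure `Nc1ccc(F)cc1NC(=O)c1ccc(CNC(=O)/C=C/c2cnc3cccnn23)cc1`, gives 812 nM in this assay. Compound 1 holds the lower of the two numbers, but its gap to compound 2 lies within the scatter, so the two cannot be ranked against each other.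

Compound 3, with the structure `Cc1nc2ccccn2c1/C=C/C(=O)NCc1ccc(C(=O)Nc2ccccc2N)cc1`, remains to be measured in this assay. It differs from compound 1 by a group of 10 heavy atoms (8 carbon, 2 nitrogen; one five-membered aromatic ring with 2 hetero atoms, one six-membered aromatic ring with 1 hetero atom) in place of a group of 9 heavy atoms (8 carbon, 1 nitrogen; one five-membered aromatic ring with 1 hetero atom, one six-membered aromatic ring of carbon only), on a double-bonded chain carbon bound to a double-bonded chain carbon. Within the data shown here, no pair of measured compounds differing in a single place is available, so the size of this step has to be judged from the two values alone. Since compound 2, which also carries a nitrogen-containing bicyclic group at this position, gives 812 nM, a modest shift toward weaker inhibition, or no shift beyond the scatter, is expected from compound 1 to compound 3, amounting to a 1.3-fold higher number from compound 1 to compound 3 (0.12 log units; within the scatter). Compound 3 is therefore estimated to give 850 nM in this assay, within a range of 350 nM to 2000 nM.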

Compound 3, half-maximal inhibitory concentration: 1310 nM
Estimate against measurement, compound 3: 1.5-fold (0.19 log units) below; the measured number falls inside the stated range.
By their numbers in this assay, from the lowest: compounds 1, 2 and 3 (each within the scatter of the next, the first and the last beyond it).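

In this assay, among these compounds, replacing the 1H-indol-3-yl group on the double-bonded chain carbon with the group of no common name gives a 2.0-fold higher number from compound 1 to compound 3 (0.31 log units; beyond the scatter), the first step that changes a single place. The position therefore responds to this change, but only modestly, so the indole is not essential for activity on this read-out at the level of this step. Because the exchange removes the 1 hydrogen-bond donor of the indole, adds 2 hydrogen-bond acceptors and alters both rings at once, the single step cannot assign the shift to any one of these differences, and nothing among the data shown offers an explanation for it.

The compounds shown leave open whether the indole hydrogen-bond donor matters on its own, which a 1-methylindol-3-yl group at this place would test against compound 1. They also leave open whether a fused bicyclic group is needed at all, a question that a single-ring group such as phenyl or pyridin-3-yl on the same chain carbon would address.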